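Iodo to methoxy on a weak growth inhibitor

The source may report more compounds than this note shows. Statements on the series, on what has been measured and on what is new or still open speak of the compounds shown alone.

Compound 1 `NC(=O)c1cc(Cl)ccc1NC(=O)COc1ccccc1` gives 63800 nM
Compound 2 `NC(=O)c1cc(I)ccc1NC(=O)COc1ccccc1` gives 8110 nM

In a functional assay on TK-10 cells (Homo sapiens) for inhibition (a higher number here means a weaker inhibitor of growth, a lower number a stronger inhibitor of growth), compound 2 stands at 8110 nM as the lower of the two numbers, which makes it the stronger growth inhibitor of the pair. Compound 3 `COc1ccc(NC(=O)COc2ccccc2)c(C(N)=O)c1` differs from it in one place, methoxy in place of iodo on an aromatic carbon with methoxy in place of iodo on an aromatic carbon. Among the measured compounds shown here, one measured step bears on this change, a 7.9-fold lower number from compound 1 to compound 2 (0.90 log units; beyond the scatter) as a modest swap on that same carbon. For the measured compounds named here, no measured compound carries methoxy, so only a modest move to a higher number is expected. The estimate is a 3.7-fold higher number from compound 2 to compound 3 (0.57 log units; beyond the scatter) as the likely step. For compound 3 the estimated value is 30000 nM with 9000 nM to 90000 nM as its expected range.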

Compound 3, concentration for 50% growth inhibition: 23800 nM
Compound 3: the middle estimate sits 1.3-fold (0.10 log units) above what was measured; low and high end bracket the measured number.
By their numbers in this assay, from the lowest: compound 2; then compound 3; then compound 1.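

In this assay, among the compounds shown here, methoxy is the first group on this aromatic carbon that is not a halogen, and it gives a 2.9-fold higher number from compound 2 to compound 3 (0.47 log units; beyond the scatter) and a 2.7-fold lower number from compound 1 to compound 3 (0.43 log units; beyond the scatter). The three compounds therefore rank iodo, then methoxy, then chloro, from lowest number to highest, so the number here does not depend on a halogen alone. Nothing available explains these differences. From the compounds shown here alone, whether an amine, a carboxylic acid or a longer chain such as ethoxy on this carbon would give a lower number than iodo stays open.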